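This account rests on a few compounds, and the source may have more. Where it says the series, first, only, none or still open, it means among the compounds named here.

Working notes on the series. Three compounds share the core of compound 1 `O=C(Nc1cccnc1)c1cccnc1`; compound 2 `O=C(Nc1cccnc1)c1ccccc1` and compound 3 `O=C(Nc1cccnc1)c1ccc(Cl)cc1` vary the second ring. In an assay on V79 cells for inhibition of cytochrome P450 11B2, mitochondrial (Homo sapiens), tested at 500 nM (a higher number here means more inhibition at the concentration tested (going by the name of the read-out), a lower number less inhibition), compound 1 gives 8%, compound 2 gives 30% and compound 3 gives 88%. Among the measured compounds shown here, the only single-point step measured so far is a number 58 percentage points higher from compound 2 to compound 3 (beyond the scatter), a chloro in place of hydrogen on an aromatic carbon. Compound 3 thus stands highest of the three numbers in this assay, with compound 2 nearest and compound 1 furthest, both differences beyond the scatter.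

Compound 4 `O=C(Nc1cccnc1)c1ccc(OC(F)(F)F)cc1` is not yet measured. It differs from compound 3 as follows: trifluoromethoxy in place of chloro on an aromatic carbon. For the measured compounds named here, no measured step covers a trifluoromethoxy in place of chloro on an aromatic carbon; the one step that bears on it, a number 58 percentage points higher from compound 2 to compound 3 (beyond the scatter), only shows that filling this position of the six-membered aromatic ring of carbon only with a group raised the number from the bare ring. Compound 4 keeps that position occupied, so in this assay compound 4 is expected to stay close to compound 3, a step of a number 8 percentage points lower from compound 3 to compound 4 (within the scatter), within or near the scatter. The estimate for compound 4 is 80%, with a range from 55% to 95%.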

Compound 4, a percentage reported as inhibition, at one concentration (the size of the read-out at that concentration, not a potency): 3%
Compound 4: the middle estimate sits 77 percentage points above what was measured, outside the stated range (below it).
By their numbers in this assay, from the lowest: compounds 4 and 1 (each within the scatter of the next); then compound 2; then compound 3.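

Keeping this position occupied does not hold the number up: in this assay trifluoromethoxy in place of chloro gives a number 85 percentage points lower from compound 3 to compound 4 (beyond the scatter) and the two groups are not interchangeable here. Trifluoromethoxy in place of hydrogen gives a number 27 percentage points lower from compound 2 to compound 4 (beyond the scatter) while chloro in place of hydrogen gives a number 58 percentage points higher from compound 2 to compound 3 (beyond the scatter) so this position moves the number up or down depending on the group that fills it. No measurement at hand accounts for this split between the two groups.

The compounds shown leave open whether the fall goes with the oxygen or with the three fluorines of the new group, which a methoxy or a trifluoromethyl group on this carbon would help to separate. Also open, going by these compounds, is whether a bromo or a methyl group here would track chloro or trifluoromethoxy.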